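Replacing the acid on the shared core: compound 2 to 4

The compounds below may be only part of what the source reports. "The series", "measured", "known", "first", "only" and "open" are said of these compounds alone.

Of the compounds shown here, three share a core and have been measured in an ADME assay on the whole organism (plasma, Macaca fascicularis) for protein binding, read by LC-MS, using equilibrium dialysis and cassette dosing, with a stated time of 24 h, at a dose of 1 mg/kg by the oral route; a higher number here means a larger unbound share of the compound, a lower number a smaller unbound share. Compound 1 `C[C@H](c1ccc(-c2cc(Cl)ccc2-c2nc(=O)o[nH]2)cc1)N(CC1CC1)c1nc2c(C(=O)O)cccc2o1` gives 0.000108. For the measured compounds named here, compound 3 `Cc1ccc(-c2nc(=O)o[nH]2)c(-c2ccc([C@@H](C)N(CC3CC3)c3nc4c(C(=O)O)cccc4o3)cc2)c1` gives 0.00023, and the only single-point step among them, a 2.1-fold higher number from compound 1 to compound 3 (0.33 log units; beyond the scatter), is a methyl in place of a chloro. Compound 2 `CCCCN(c1nc2c(C(=O)O)cccc2o1)[C@H](C)c1ccc(-c2ccccc2-c2nnn[nH]2)cc1` gives 0.000285, the highest of the three numbers; its gap to compound 3 is within the scatter, while its gap to compound 1 lies beyond it.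

Compound 4 `CCCCN(c1nc2c(-c3nccn3C)cccc2o1)[C@H](C)c1ccc(-c2ccccc2-c2nnn[nH]2)cc1` differs from compound 2 at one place: 1-methyl-1H-imidazol-2-yl in place of carboxy on an aromatic carbon. Going by the values given here, none of the measured steps bears on this change; the one step known concerns a small substituent on a different ring and says nothing about exchanging the carboxy group for a ring. The expectation therefore rests on the value of compound 2 alone, with wide uncertainty. The step from compound 2 to compound 4 in this assay is estimated as a 2.8-fold higher number from compound 2 to compound 4 (0.45 log units; beyond the scatter). Compound 4 is expected to give 0.0008, within the range 0.0002 to 0.004.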

Compound 4, unbound fraction: 0.00299
Compound 4: middle estimate off by 3.7-fold (0.57 log units), on the low side, within the range that was stated.
By their numbers in this assay, from the lowest: compound 1; then compounds 3 and 2 (each within the scatter of the next); then compound 4.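

Compounds 1, 2 and 3 all carry the carboxy group at this position, so compound 4 gives the first view of what a change there does in this assay. Exchanging carboxy for 1-methyl-1H-imidazol-2-yl produces a 10-fold higher number from compound 2 to compound 4 (1.02 log units; beyond the scatter) and so makes this position, in this series, a place where a single exchange can shift the unbound share by a large step. The exchange replaces a group that has a hydrogen-bond donor with a larger aromatic ring that has none, but no measurement at hand explains the rise.

One step cannot show which part of this exchange matters, and a primary amide or a methyl ester at the same position would give further points of comparison. As far as these compounds go, whether the same exchange has a similar effect on compound 1 or compound 3 also remains open.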